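Solubility notes on compounds 1 to 4

This account rests on a few compounds, and the source may have more. Where it says the series, first, only, none or still open, it means among the compounds named here.

Measured so far:
compound 1 `COc1cccc(C(C)Sc2nc3c(cnn3C)c(=O)n2-c2ccccc2)c1` — < 2000 nM
compound 2 `Cn1ncc2c(=O)n(-c3ccccc3)c(SCc3cccc(F)c3)cc21` — 178000 nM
compound 3 `CC(Sc1nc2nn(C3COC3)cc2c(=O)n1-c1ccccc1)c1cccnc1` — 189000 nM

In a physicochemical assay for solubility, using the shake flask method, in phosphate buffer, with a stated time of 24 h, at pH 7.4 (a higher number here means a more soluble compound, a lower number a less soluble compound), compound 1 gives < 2000 nM, which is a limit of the assay and not a number. Compound 1 therefore sits at the bottom of the values shown, as the limit of < 2000 nM in this assay, at which 1 of the 3 values shown sits, records. In this assay compound 2 gives 178000 nM and compound 3 gives 189000 nM; these two values lie within the scatter of each other, so no order between them is claimed.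

Compound 4 `CC(Sc1nc2c(cnn2C)c(=O)n1-c1ccccc1)c1cccnc1` has not yet been measured in this assay. It differs from compound 1 in a single place: pyridin-3-yl in place of 3-methoxyphenyl on a saturated chain carbon bound to a saturated chain carbon and a sulfur. Compound 3 also carries a pyridin-3-yl group on the chain carbon, but it differs from compound 4 elsewhere as well, so it is only a partial guide.

The step from compound 1 to compound 4 is expected to be upward and beyond the scatter, an at least 15-fold higher number from compound 1 to compound 4 (1.17 log units; beyond the scatter). Compound 4 is estimated at 30000 nM, with a range from 5000 nM to 150000 nM.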

Compound 4, solubility: 209000 nM
The estimate for compound 4 lay 7.0-fold (0.84 log units) below the measured number, outside the stated range (above it).
By their numbers in this assay, from the lowest: compounds 2, 3 and 4 (each within the scatter of the next). At a limit, below all of these: compound 1.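

In this assay, going by these compounds alone, pyridin-3-yl in place of 3-methoxyphenyl on a saturated chain carbon bound to a saturated chain carbon and a sulfur gives an at least 100-fold higher number from compound 1 to compound 4 (2.01 log units; beyond the scatter), the first comparison between compounds that differ in one place. With this single change, compound 4 joins compounds 2 and 3 in a group whose values each lie within the scatter of the next. The value of compound 1 is a limit of the assay and not a number, so the full size of the step cannot be read, because only its lower bound is fixed: the limit of < 2000 nM in this assay, at which 1 of the 4 values shown sits.

One pair cannot show whether the step would hold with other groups elsewhere on the core, or which difference between the two exchanged groups accounts for it. As far as these compounds go, how a carboxylic acid or an amine at this same place would read in this assay also remains open.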